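The compounds below may be only part of what the source reports. "The series", "measured", "known", "first", "only" and "open" are said of these compounds alone.

Measured so far:
- compound 2 `CC1=NC(C)=C(C(=O)O)C(c2cccc(Cl)c2)/C1=C(\O)OC/C=C/C1CCCCC1`, 830 nM in a functional assay on IMR-32 cells for inhibition of Voltage-dependent N-type calcium channel subunit alpha-1B (Homo sapiens), read by calcium flux; on this read-out higher numbers stand for weaker inhibition and lower numbers for stronger inhibition
- compound 1 `COC(=O)c1cccc(C2C(C(=O)O)=C(C)N=C(C)/C2=C(/O)OC/C=C/c2ccccc2)c1`, 4600 nM in this assay

Of these two, compound 2 has the lower number, and the gap to compound 1 lies beyond the usual scatter, so compound 2 is the stronger inhibitor among the measured pair. Compound 3 `CC1=NC(C)=C(C(=O)O)C(c2cccc(Cl)c2)/C1=C(\O)OCc1ccc2ccccc2c1` differs from compound 2 in one place: naphthalen-2-yl in place of 2-cyclohexylethenyl on a saturated chain carbon bound to an oxygen on an unsaturated carbon. For the measured compounds named here, no measured pair shows what such a change does here, so the expectation rests on compound 2 alone. Compound 3 is expected to land near compound 2, with the step of a 1.4-fold higher number from compound 2 to compound 3 (0.16 log units; within the scatter) not beyond the scatter. For compound 3 the estimate is 1200 nM, between 400 nM and 3500 nM.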

Compound 3, half-maximal inhibitory concentration: 1000 nM
Compound 3: the middle estimate sits 1.2-fold (0.08 log units) above what was measured, and the stated range covers the measured number.
By their numbers in this assay, from the lowest: compounds 2 and 3 (each within the scatter of the next); then compound 1.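

Replacing 2-cyclohexylethenyl with naphthalen-2-yl at this position gives a 1.2-fold higher number from compound 2 to compound 3 (0.08 log units; within the scatter) in this assay. This position therefore accepts two aromatic rings as well as a non-aromatic ring on a double bond, and in this pair the double bond outside aromatic rings is not needed to keep inhibition at this level. Nothing measured here explains why the two groups read alike.

From the compounds shown here alone, whether a much smaller group such as methyl, or a chain ending in an amine, would fit this position equally well remains open.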